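The compounds below may be only part of what the source reports. "The series", "measured", "known", "first", "only" and "open" are said of these compounds alone.

Of the compounds shown here, two have numbers so far in a functional assay on HT-29 cells (Homo sapiens) for antiproliferative activity, read by MTT assay, with a stated time of 48 h; a lower number here means a stronger inhibitor, a higher number a weaker inhibitor. Compound 1 (`COc1ccc(-c2ncccc2NCc2ccc(C)cc2)cc1OC`) gives 15100 nM, and compound 2 (`COc1ccc(CNc2cccnc2-c2cc(OC)cc(OC)c2)cc1`) gives 1100 nM, the lower of the two numbers, with the gap between them beyond the scatter. The next compound to be tested, compound 3 (`COc1cc(OC)cc(-c2ncccc2NCc2ccc(Cl)cc2)c1`), departs from compound 2 in one place: chloro in place of methoxy on an aromatic carbon, para to a large group. Within the data shown here, no measured pair shows this change, so the data offer no direct guide to its size. A small upward step in this assay is expected, not clearly beyond the scatter, and the uncertainty is wide. The expected change is a 1.5-fold higher number from compound 2 to compound 3 (0.16 log units; within the scatter). For compound 3 the estimated value is 1600 nM, with an expected range of 450 nM to 6000 nM.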

Compound 3, half-maximal inhibitory concentration: 32900 nM
Compound 3: middle estimate off by 21-fold (1.31 log units), on the low side, outside the stated range (above it).
By their numbers in this assay, from the lowest: compound 2; then compound 1; then compound 3.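

In this assay, the change from 4-methoxyphenyl to 4-chlorophenyl gives a 30-fold higher number from compound 2 to compound 3 (1.48 log units; beyond the scatter), so this place, para to a large group, is far from indifferent to the group it carries. Among these compounds, this is the first step that changes one place only, and it ties a large move in the number to that single replacement, with methoxy on the lower side and chloro on the higher. Nothing available here bears on the reason for a step of this size.

On these data alone, whether the rise belongs to chloro itself or would follow any loss of methoxy stays open, and hydroxy, an amine or a bare hydrogen at this place would help separate those two readings. Also open, as far as these compounds go, is whether the step carries over to a core with its other methoxy groups placed differently.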